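A ring group swapped on a saturated chain carbon

A few compounds are considered here, and "the series" means these few. Any claim that something is new, unique, unknown or untested is made for them only; others in the source may bear on it.

- Compound 1 `CC(C)C(/C=C1\NC(=O)NC1=O)c1ccc(-c2ccc3cccc(F)c3c2)[nH]c1=O`: 7500 nM
- Compound 2 `CC(C)C(c1ccc(-c2ccc3cccc(F)c3c2)[nH]c1=O)C1C(=O)NC(=O)N1C`: 13600 nM

Only these two numbers exist so far in a physicochemical assay for solubility, measured as kinetic solubility, at pH 2 (on this read-out lower numbers stand for lower solubility and higher numbers for higher solubility), and compound 2 stands within the usual scatter of compound 1, so neither can be ranked above the other. The next molecule is compound 3 `CC(C)C(/C=C1/C(=O)NC(=O)N1C)c1ccc(-c2ccc3cccc(F)c3c2)[nH]c1=O`. It keeps the shared core of compound 2 and changes one group: a group of 9 heavy atoms (5 carbon, 2 nitrogen, 2 oxygen; one five-membered non-aromatic ring with 2 hetero atoms) in place of a group of 8 heavy atoms (4 carbon, 2 nitrogen, 2 oxygen; one five-membered non-aromatic ring with 2 hetero atoms), on a saturated chain carbon bound to an aromatic carbon and a saturated chain carbon. Within the data shown here, one measured step bears on this change, because a 1.8-fold higher number from compound 1 to compound 2 (0.26 log units; within the scatter) also exchanges one five-membered non-aromatic ring group for another at the same place. A single step is thin evidence, but it gives no reason to expect a step beyond the scatter in this assay, in either direction. The expected step is a 1.4-fold lower number from compound 2 to compound 3 (0.13 log units; within the scatter). The estimate for compound 3 is 10000 nM, with an expected range of 4000 nM to 25000 nM.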

Compound 3, solubility: 8300 nM
The estimate for compound 3 lay 1.2-fold (0.08 log units) above the measured number, within the range that was stated.
By their numbers in this assay, from the lowest: compounds 1, 3 and 2 (each within the scatter of the next).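

In this assay, the group with one more double bond outside aromatic rings, entering on the saturated chain carbon in place of 3-methyl-2,5-dioxoimidazolidin-4-yl, gives a 1.6-fold lower number from compound 2 to compound 3 (0.21 log units; within the scatter) and so adds a second ring swap at this place that stays within the scatter. The new comparison that isolates a single small change, methyl in place of hydrogen on an amide-type nitrogen in a ring, gives a 1.1-fold higher number from compound 1 to compound 3 (0.04 log units; within the scatter) and also stays within the scatter. Nothing measured here accounts for the size of either step.

As far as these compounds go, whether an amine, a carboxylic acid or a longer chain on this saturated chain carbon would give a step beyond the scatter remains open. From the compounds shown here alone, it is also open whether the methyl step would stay this small on a different core.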